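Compound 1 to compound 4: a methoxyphenyl swap

The source may report more compounds than this note shows. Statements on the series, on what has been measured and on what is new or still open speak of the compounds shown alone.

Values so far in a functional assay on COLO 205 cells (Homo sapiens) for inhibition, read by sulforhodamine B assay, with a stated time of 48 h, tested at 50 uM; a lower number here means less inhibition of growth, a higher number more inhibition of growth at the concentration tested

Compound 1 `COc1cccc(/C=C/C(=O)/C=C/c2ccc(OCc3cn(CCCCOc4cc(=O)oc5ccccc45)nn3)c(OC)c2)c1` gives 46%
Compound 2 `COc1ccc(/C=C/C(=O)/C=C/c2ccc(OCc3cn(CCCOc4cc(=O)oc5ccccc45)nn3)c(OC)c2)cc1OC` gives 65%
Compound 3 `COc1ccc(/C=C/C(=O)/C=C/c2ccc(OCc3cn(CCCOc4cc(=O)oc5ccccc45)nn3)c(OC)c2)cc1` gives 53%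

In this assay compound 1 stands at 46%, within the scatter of compound 3 and beyond the scatter under compound 2. Compound 4 `COc1ccc(/C=C/C(=O)/C=C/c2ccc(OCc3cn(CCCCOc4cc(=O)oc5ccccc45)nn3)c(OC)c2)cc1` has not yet been measured. It holds the same atoms as compound 1, joined differently: 4-methoxyphenyl in place of 3-methoxyphenyl on a double-bonded chain carbon bound to a double-bonded chain carbon. In plain terms, 4-methoxyphenyl takes the place of 3-methoxyphenyl on a double-bonded chain carbon bound to a double-bonded chain carbon.

For the measured compounds named here, no measured pair makes this exact change. Going by the values given here, the only measured step is a number 12 percentage points lower from compound 2 to compound 3 (beyond the scatter), with hydrogen in place of methoxy on an aromatic carbon. That step is modest, though beyond the scatter, and it removes a group, whereas the change to compound 4 removes none. A step of no greater size is therefore expected here. Compound 3 also carries 4-methoxyphenyl, but it is not otherwise the same as compound 4, and compound 3 at 53% gives only a weak hint of a slight rise. The expected step is a number 4 percentage points higher from compound 1 to compound 4 (within the scatter), which would stay within the scatter. The estimate for compound 4 is 50%, with an expected range from 38% to 62%.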

Compound 4, percent growth inhibition at one concentration: 49%
The estimate for compound 4 lay 1 percentage points above the measured number; the range from low to high includes it.
By their numbers in this assay, from the lowest: compounds 1, 4 and 3 (each within the scatter of the next); then compound 2.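

Setting 4-methoxyphenyl in place of 3-methoxyphenyl on a double-bonded chain carbon bound to a double-bonded chain carbon gives a number 3 percentage points higher from compound 1 to compound 4 (within the scatter) in this assay, so this assay does not separate these two groups at this place. For the compounds shown here, this is the first measured pair to change this place, and here the atoms stay the same and only their joining differs, whereas the one earlier step, a number 12 percentage points lower from compound 2 to compound 3 (beyond the scatter), puts hydrogen in place of methoxy on an aromatic carbon and lies beyond the scatter. The compounds offer no measurement that would explain either result.

The compounds shown leave open whether a group other than methoxy on this phenyl ring, such as a hydroxyl, a dimethylamino group or a chlorine, would give a step beyond the scatter at this place. They also leave open whether the near-equal readings of compound 1 and compound 4 would hold in a series with a longer chain between the triazole and the far end of the molecule.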